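The compounds below may be only part of what the source reports. "The series", "measured", "known", "first", "only" and "open" are said of these compounds alone.

Measured compounds: compound 1 `COc1ccc(C2CC(c3ccc(OC)c(OC)c3)=NN2C(=O)CO[N+](=O)[O-])c(OC)c1` gives 48% in a functional assay on the whole organism (strain albino) for inhibition, with Rattus norvegicus as the target, read by paw edema, with stated times of 30 min and 2 h, at a dose of 100 mg/kg by the oral route; a lower number here means less inhibition, a higher number more inhibition at the dose given (going by the name of the read-out); compound 2 `COc1ccc(C2=NN(C(=O)CO[N+](=O)[O-])C(c3c(Cl)cccc3Cl)C2)cc1OC` gives 49%; compound 3 `COc1ccc(C2CC(c3ccc(OC)c(OC)c3)=NN2C(=O)C(C)O[N+](=O)[O-])c(OC)c1` gives 61%.

The change from compound 1 to compound 2, (2,6-dichlorophenyl in place of 2,4-dimethoxyphenyl on a saturated ring carbon), made a step of a number 1 percentage points higher from compound 1 to compound 2 (within the scatter). The cores of compound 1 and compound 3 differ by methyl in place of hydrogen on a saturated chain carbon bound to a carbonyl carbon and an oxygen on an unsaturated carbon, a step of a number 13 percentage points higher from compound 1 to compound 3 (beyond the scatter). Compound 4 `COc1ccc(C2=NN(C(=O)C(C)O[N+](=O)[O-])C(c3c(Cl)cccc3Cl)C2)cc1OC` carries the same kind of change, (2,6-dichlorophenyl in place of 2,4-dimethoxyphenyl on a saturated ring carbon), but around its place the ring atom bears a group of 8 heavy atoms rather than a ((nitrooxy)methyl)carbonyl group (7 heavy atoms). Because the earlier step of a number 1 percentage points higher from compound 1 to compound 2 (within the scatter) lay within the scatter, the step from compound 3 to compound 4 is expected to be a number 1 percentage points higher from compound 3 to compound 4 (within the scatter). Compound 4 is thus estimated at 62%, between 50% and 73%.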

Compound 4, a percentage reported as inhibition, in the whole organism at one dose (the size of the read-out at that dose, not a potency): 53%
Compound 4: the middle estimate sits 9 percentage points above what was measured, within the range that was stated.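

In this assay, among these compounds, putting 2,6-dichlorophenyl in place of 2,4-dimethoxyphenyl gives a number 8 percentage points lower from compound 3 to compound 4 (within the scatter), and the two cores do not clearly differ in how they take this change: the same change on two cores in this assay, a number 1 percentage points higher (within the scatter) from compound 1 to compound 2 and a number 8 percentage points lower (within the scatter) from compound 3 to compound 4, 9 percentage points apart, within the scatter of two such steps Adding the methyl on the chain carbon gives a number 4 percentage points higher from compound 2 to compound 4 (within the scatter), and again the two cores do not clearly differ: the same change on two cores in this assay, a number 13 percentage points higher (beyond the scatter) from compound 1 to compound 3 and a number 4 percentage points higher (within the scatter) from compound 2 to compound 4, 9 percentage points apart, within the scatter of two such steps This does not show that either change would carry over to a further core, since only two cores are compared, and the methyl step passes beyond the scatter on just one of them.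

The compounds shown leave open how an ethyl group in place of that methyl would read in this assay. They also leave open the effect of an amine in place of the nitrooxy group.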